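The compounds below may be only part of what the source reports. "The series", "measured", "known", "first", "only" and "open" are said of these compounds alone.

Three compounds have numbers in a functional assay on LoVo cells (Homo sapiens) for inhibition, read by colorimetric assay and MTT assay, with a stated time of 72 h; a higher number here means a weaker inhibitor, a lower number a stronger inhibitor. Compound 1 (`C=CCCCCOc1ccc(OC)cc1-c1cnc(OCCC=C)n1C`) gives 33000 nM, and compound 2 (`C=CCCCCOc1cc(F)ccc1-c1cnc(OCCC=C)n1C`) gives 45000 nM. Compound 3 (`C=CCCCCOc1ncc(-c2cc(C(C)C)ccc2OC)n1C`) gives 3000 nM, the lowest number of the three and clearly beyond the scatter from both others. Compound 4 (`C=CCCCCOc1ncc(-c2cc(C(F)(F)F)ccc2OC)n1C`) carries trifluoromethyl in place of isopropyl on an aromatic carbon, para to a methoxy group: trifluoromethyl in place of isopropyl on an aromatic carbon. Among the compounds with values here, no measured pair of compounds differs in one place only, so nothing here shows directly what such a swap does, and any expectation is loose. The expected change, a 2.0-fold higher number from compound 3 to compound 4 (0.30 log units; within the scatter), is a modest rise in the number, near the edge of the scatter. For compound 4 the estimated value in this assay is 6000 nM, with an expected range of 2000 nM to 18000 nM.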

Compound 4, half-maximal inhibitory concentration: 51000 nM
Estimate against measurement, compound 4: 8.5-fold (0.93 log units) below; the measured number lies above the stated range.
By their numbers in this assay, from the lowest: compound 3; then compounds 1, 2 and 4 (each within the scatter of the next).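

Within the data shown here, this is the first direct reading of a single change at this position: in this assay, trifluoromethyl in place of isopropyl gives a 17-fold higher number from compound 3 to compound 4 (1.23 log units; beyond the scatter) and so the step is large and clearly beyond the scatter. The group on this aromatic carbon, para to a methoxy group, therefore matters greatly for this pair, though one pair shows no general trend. Nothing measured here gives a reason for the size of this step. Going by these compounds, whether a methyl group, a tert-butyl group or an amine at this position would keep the number of compound 3 stays open. So does whether the same swap would have a similar effect with a longer chain elsewhere on the shared core.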